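The compounds below may be only part of what the source reports. "The series", "measured", "known", "first", "only" and "open" are said of these compounds alone.

Measured so far in a functional assay on HCT-116 cells (Homo sapiens) for inhibition; a higher number here means that more compound is needed for the effect, a lower number that less compound is needed
compound 1 `COc1cc(N2CCC(C(=O)N3CCC(N(C)C)C3)CC2)ccc1Nc1nc(NC2CCCCC2)c2nc[nH]c2n1` gives 77 nM
compound 2 `COc1cc(N2CCC(CC(=O)N3CCN(C)CC3)CC2)ccc1Nc1nc(NC2CCCCC2)c2nc[nH]c2n1` gives 65 nM
compound 3 `COc1cc(N2CCC(CC(=O)N3CCCC3)CC2)ccc1Nc1nc(NC2CCCCC2)c2nc[nH]c2n1` gives 26 nM

Compound 3 holds the lowest number of the three, and both a 3.0-fold lower number from compound 1 to compound 3 (0.47 log units; beyond the scatter) and a 2.5-fold lower number from compound 2 to compound 3 (0.40 log units; beyond the scatter) are modest steps beyond the scatter. Within the data shown here, compound 4 `COc1cc(N2CCC(C(=O)N3CC(O)C3)CC2)ccc1Nc1nc(NC2CCCCC2)c2nc[nH]c2n1` has no measurement yet. The change is (3-hydroxyazetidin-1-yl)carbonyl in place of ((pyrrolidin-1-yl)carbonyl)methyl on a saturated ring carbon with (3-hydroxyazetidin-1-yl)carbonyl in place of ((pyrrolidin-1-yl)carbonyl)methyl on a saturated ring carbon. Among the measured compounds shown here, no measured compound carries the 3-hydroxyazetidin-1-yl group, so that part of the change has no direct precedent. For the measured compounds named here, compound 1 is the only measured compound with its carbonyl directly on the saturated ring carbon, which makes a 3.0-fold lower number from compound 1 to compound 3 (0.47 log units; beyond the scatter) the closest guide, although that step also changes the amine part. The step of a 2.5-fold lower number from compound 2 to compound 3 (0.40 log units; beyond the scatter) shows that the amine part alone can shift the number, while a 1.2-fold lower number from compound 1 to compound 2 (0.07 log units; within the scatter) stays within the scatter. A modest step toward a higher number is therefore expected in this assay and the expected move is a 2.1-fold higher number from compound 3 to compound 4 (0.33 log units; beyond the scatter) on this thin evidence. For compound 4 the estimated value is 55 nM with an expected range from 20 nM to 150 nM for the coming measurement.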

Compound 4, half-maximal effective concentration: 260 nM
Estimate against measurement, compound 4: 4.7-fold (0.67 log units) below; measured number outside the range, above it.
By their numbers in this assay, from the lowest: compound 3; then compounds 2 and 1 (each within the scatter of the next); then compound 4.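

In this assay, among these compounds, the amine part of the amide matters even with the carbonyl held directly on the saturated ring carbon: the replacement of 3-(dimethylamino)pyrrolidin-1-yl by 3-hydroxyazetidin-1-yl gives a 3.4-fold higher number from compound 1 to compound 4 (0.53 log units; beyond the scatter), the only new step that changes the amine part alone. The two other new steps, a 4.0-fold higher number from compound 2 to compound 4 (0.60 log units; beyond the scatter) and a 10-fold higher number from compound 3 to compound 4 (1.00 log units; beyond the scatter), also point upward and place compound 4 highest of the four, beyond the scatter from each of the others, but each changes both the amine part and the attachment of the carbonyl to the ring. No measured evidence on the compounds explains why the number rises at this position.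

How much of the largest step belongs to the amine part and how much to the attachment of the carbonyl remains unresolved, and 3-hydroxyazetidin-1-yl on the ((...)carbonyl)methyl chain of compound 3 would separate the two. Within the amine part, azetidin-1-yl without the hydroxy group and 3-hydroxypyrrolidin-1-yl would show whether the hydroxy group or the four-membered ring tracks with the higher number.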